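The compounds below may be only part of what the source reports. "The series", "measured", "known", "first", "only" and "open" are said of these compounds alone.

Measured in a functional assay on HCT-116 cells (Homo sapiens), read by MTT assay, with a stated time of 72 h; on this read-out lower numbers stand for stronger inhibition and higher numbers for weaker inhibition:
Compound 1 `Cc1ncnc2c1c(-c1cccs1)cn2[C@@H]1O[C@H](CO)[C@@H](O)[C@H]1O` gives > 20000 nM, which is a limit of the assay and not a number.
Compound 2 `Cc1ncnc2c1c(-c1ccsc1)cn2[C@@H]1O[C@H](CO)[C@@H](O)[C@H]1O` gives 460 nM.

For the measured compounds named here, compound 2 carries the only actual number so far in this assay. Compound 3 `Cc1ncnc2c1c(-c1cc3ccccc3o1)cn2[C@@H]1O[C@H](CO)[C@@H](O)[C@H]1O` differs from it as follows: 1-benzofuran-2-yl in place of thiophen-3-yl on an aromatic carbon. Going by the values given here, the one measured step bearing on this is an at least 43-fold lower number from compound 1 to compound 2 (1.63 log units; beyond the scatter), a large one at the same aromatic carbon. The entering 1-benzofuran-2-yl is again a 2-yl group, like the thiophen-2-yl on the weak side of that step, so weaker inhibition is expected. The expected change is a 13-fold higher number from compound 2 to compound 3 (1.12 log units; beyond the scatter). For compound 3 the estimate is 6000 nM, with an expected range of 1000 nM to 20000 nM.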

Compound 3, half-maximal inhibitory concentration: > 20000 nM
Compound 3: a limit, no number; the forecaster's own chance of this, stated with the estimate: 45%; middle value at least 3.3-fold (0.52 log units) away from the limit.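

Replacing thiophen-3-yl with 1-benzofuran-2-yl on this aromatic carbon gives an at least 43-fold higher number from compound 2 to compound 3 (1.63 log units; beyond the scatter), so the loss seen with thiophen-2-yl in compound 1 is not confined to that one group. Compound 1 and compound 3 each stand at a limit of the assay and not at a number, so the step between them cannot be read: the limit of > 20000 nM in this assay, at which 2 of the 3 values shown sit.

The compounds shown do not separate the attachment through the 2-yl carbon from the added six-membered aromatic ring in compound 3. Also open, from the compounds shown here alone, is whether 1-benzofuran-3-yl, or thiophen-3-yl carrying an amine, keeps the inhibition of compound 2.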